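The compounds below may be only part of what the source reports. "The series", "measured", "known", "first", "only" and "open" are said of these compounds alone.

Measured compounds in a functional assay on the whole organism for activation, with Mus musculus as the target; a higher number here means that more compound is needed for the effect, a lower number that less compound is needed:

- compound 1 `Cc1nc(N)c2nc(O)n(Cc3ccccc3)c2n1`: 3 mg/kg
- compound 2 `CCCCCOc1nc(N)c2nc(O)n(Cc3ccccc3)c2n1`: 0.3 mg/kg
- compound 3 `CCCc1nc(N)c2nc(O)n(Cc3ccccc3)c2n1`: 3 mg/kg

Compound 1 stands level with compound 3 in this assay at the digits given, the two together the highest numbers of the three; its furthest neighbour is compound 2, reached by a 10-fold lower number from compound 1 to compound 2 (1.00 log units; beyond the scatter).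

Compound 4 `CCCC[S+]([O-])c1nc(N)c2nc(O)n(Cc3ccccc3)c2n1` is not yet measured. Against compound 1 the change is a group of 6 heavy atoms (4 carbon, 1 oxygen, 1 sulfur; no ring) in place of one carbon atom, on an aromatic carbon.

Among the measured compounds shown here, two steps bear on it. The step of a 10-fold lower number from compound 1 to compound 2 (1.00 log units; beyond the scatter), pentyloxy in place of methyl on the same aromatic carbon, shows that a chain carrying a hydrogen-bond acceptor at that position goes with a lower number; the reverse, a 10-fold higher number from compound 2 to compound 3 (1.00 log units; beyond the scatter), propyl in place of pentyloxy, undoes it. Lengthening the carbon chain alone, no change at the digits printed from compound 1 to compound 3 (within the scatter), does nothing beyond the scatter. The entering group of compound 4 is again a chain with an acceptor, so a lower number than compound 1 is expected, though with a single precedent a smaller step than a 10-fold lower number from compound 1 to compound 2 (1.00 log units; beyond the scatter) is expected. The step expected is a 3.0-fold lower number from compound 1 to compound 4 (0.48 log units; beyond the scatter). Compound 4 is therefore estimated at 1 mg/kg, within 0.3 mg/kg to 3 mg/kg.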

Compound 4, minimum effective dose: 1 mg/kg
Estimate against measurement, compound 4: no gap at the digits printed; measured number inside the range.
By their numbers in this assay, from the lowest: compound 2; then compound 4; then compounds 1 and 3 (each within the scatter of the next).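

In this assay, a second chain bearing a hydrogen-bond acceptor, here with sulfur and oxygen, gives a 3.0-fold lower number from compound 1 to compound 4 (0.48 log units; beyond the scatter) and a 3.0-fold lower number from compound 3 to compound 4 (0.48 log units; beyond the scatter), so a lower number at this aromatic carbon is not confined to the pentyloxy group. The gain is not the same for both chains, however: a 3.3-fold higher number from compound 2 to compound 4 (0.52 log units; beyond the scatter) separates two groups of equal heavy-atom count, so that count alone does not set the number. No measurement shown accounts for these steps.

The four compounds cannot separate the effect of the atom bound to the aromatic carbon from that of chain length, since a butoxy group and a butylthio group both lie outside them. From the compounds shown here alone, how an amine or a longer chain bound through sulfur would behave at this position also remains open.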